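Two inverted stereocentres: from compound 3 to compound 4

This account rests on a few compounds, and the source may have more. Where it says the series, first, only, none or still open, it means among the compounds named here.

Three compounds that differ only in configuration have been followed in a physicochemical assay for metabolic stability, read by HPLC, in phosphate buffer, with a stated time of 12 h, at pH 7.2; on this read-out higher numbers stand for a longer-lived compound and lower numbers for a shorter-lived compound: compound 1 `O=C(O)[C@@H](CO)NC(=O)[C@H]1C[C@@H](O)CN1`, compound 2 `O=C(O)[C@@H](CO)NC(=O)[C@H]1C[C@H](O)CN1` and compound 3 `O=C(O)[C@H](CO)NC(=O)[C@@H]1C[C@H](O)CN1`. Compound 1 gives > 12 h, which is a limit and not a number. Compound 2 gives > 12 h, also a limit. Compound 3 gives > 12 h, again only a limit.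

Compound 4 `O=C(N[C@H](CO)C(=O)O)[C@@H]1C[C@@H](O)CN1` departs from compound 3 in configuration alone: the two compounds have the same atoms and bonds and differ only in configuration as drawn: 2 of 3 stereo elements differ; a stereocentre at a saturated chain carbon is drawn S in compound 3 and R in compound 4; a stereocentre at a saturated ring carbon is drawn S in compound 3 and R in compound 4. The measured steps that bear on this are a step that the two limits leave unreadable from compound 1 to compound 2, a step that the two limits leave unreadable from compound 1 to compound 3 and a step that the two limits leave unreadable from compound 2 to compound 3. None of these changes of configuration took a compound off (the limit of > 12 h in this assay, at which 3 of the 3 values shown sit). The last of them also involves a stereocentre at a saturated chain carbon and one at a saturated ring carbon, so no change beyond the scatter, in either direction, is expected in this assay.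

The step expected is a step that the limit leaves unreadable from compound 3 to compound 4. Compound 4 is estimated at 24 h, with an expected range from 12 h to 48 h, and the assay will probably report only a limit.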

Compound 4, half-life: > 12 h
Compound 4 was reported as a limit (the forecaster's own chance of this, stated with the estimate: 90%); the middle value is on the limit's open side.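

No step from compound 1, compound 2 or compound 3 to compound 4 can be read in this assay, as each value is a limit and not a number: the limit of > 12 h in this assay, at which 4 of the 4 values shown sit.

The compounds shown leave open whether these four configurations differ at all in half-life.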